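Methoxy in place of hydrogen: cytotoxicity working notes

The source may hold more compounds than are shown below. What is called first, only, known or untested is meant among the compounds shown, and "the series" means these compounds.

All values below come from an ADME assay on NIH3T3 cells (Mus musculus) for cytotoxicity, read by MTT assay, with a stated time of 24 h; on this read-out higher numbers stand for weaker inhibition and lower numbers for stronger inhibition.

compound 1 `O=C(CN1CCN(c2ccccc2)CC1)N1CCN(c2nnc(-c3ccccc3)c(-c3ccccc3)n2)CC1`: > 963000 nM.
compound 2 `COc1cccc(N2CCN(CC(=O)N3CCN(c4nnc(-c5ccccc5)c(-c5ccccc5)n4)CC3)CC2)c1`: 361000 nM.
compound 3 `Cc1ccc(-c2nnc(N3CCN(C(=O)CN4CCN(c5ccccc5)CC4)CC3)nc2-c2ccc(C)cc2)cc1`: > 914000 nM.

For compound 1 the value > 963000 nM is a limit of this assay and not a number (the limit of > 963000 nM in this assay, at which 1 of the 3 values shown sits). For compound 3 the value > 914000 nM is likewise a limit (the limit of > 914000 nM in this assay, at which 1 of the 3 values shown sits). Among the compounds with values here, only compound 2 gives a number in this assay, so only one measured step can be read: an at least 2.6-fold lower number from compound 1 to compound 2 (0.42 log units; beyond the scatter), made by methoxy in place of hydrogen on an aromatic carbon.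

The difference between the core of compound 1 and the core of compound 3 is not broken down here.

Compound 4 `COc1ccccc1N1CCN(CC(=O)N2CCN(c3nnc(-c4ccc(C)cc4)c(-c4ccc(C)cc4)n3)CC2)CC1` is not yet measured. It differs from compound 3 by methoxy in place of hydrogen on an aromatic carbon. Within the data shown here, the change is the same kind of change as the one from compound 1 to compound 2, not the same: there the methoxy enters meta to a large group, here ortho to a large group, and the ring itself carries other substituents in compound 3 and compound 4.

Among the measured compounds shown here, because the only measured step of this kind is an at least 2.6-fold lower number from compound 1 to compound 2 (0.42 log units; beyond the scatter), compound 4 is expected to sit at a lower number than compound 3, by an estimated at least 2.0-fold lower number from compound 3 to compound 4 (0.30 log units; that floor lies within the scatter). On these data alone, since compound 3 gives only a limit, the starting point is unknown, and a limit for compound 4 remains possible. Compound 4 is estimated at 450000 nM, expected between 150000 nM and 1000000 nM.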

Compound 4, half-maximal inhibitory concentration: 133000 nM
Compound 4: middle estimate off by 3.4-fold (0.53 log units), on the high side, outside the stated range (below it).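

In this assay, within the data shown here, methoxy in place of hydrogen on an aromatic carbon again goes with a lower number, an at least 6.8-fold lower number from compound 3 to compound 4 (0.83 log units; beyond the scatter), so the direction seen on the core of compound 1 is also seen on the core of compound 3, in the only two pairs available. The size of the change does not carry over in any readable way, since both starting compounds give only limits and the two steps cannot be ranked: the same change on two cores in this assay, an at least 2.6-fold lower number (0.42 log units; beyond the scatter) from compound 1 to compound 2 and an at least 6.8-fold lower number (0.83 log units; beyond the scatter) from compound 3 to compound 4; the limit leaves it open whether they differ. The result therefore supports a shared direction on these two cores but no transferable size, and it cannot separate the effect of the core from that of the place of the methoxy, which in compound 4 is ortho to a large group and differs from its place in compound 2.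

The compounds shown leave open whether methoxy at one and the same place would give matching steps on both cores, and what the true distance from the starting compounds is. They also leave open whether a hydroxyl, an amine, a carboxylic acid or a longer alkoxy chain at that carbon would go with a lower number in the same way.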